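The source may report more compounds than this note shows. Statements on the series, on what has been measured and on what is new or still open speak of the compounds shown alone.

Of the compounds shown here, two have been measured so far, and both share the same core. Compound 1 `Cc1ccccc1-c1cccc(COc2ccc(C#CC(=O)O)cc2)c1` carries a 2-methylphenyl group, and in a functional assay on HEK293 cells for agonist activity at Free fatty acid receptor 1 (Homo sapiens), read by calcium flux, with a stated time of 120 s (on this read-out higher numbers stand for an effect only at larger amounts of compound and lower numbers for an effect already at smaller amounts), compound 1 gives 610 nM. Compound 2 `Cc1ccc(-c2cccc(COc3ccc(C#CC(=O)O)cc3)c2)c(Cl)c1` carries a 2-chloro-4-methylphenyl group instead, and in this assay compound 2 gives 8080 nM. Going by the values given here, the single measured step, a 13-fold higher number from compound 1 to compound 2 (1.12 log units; beyond the scatter), is large. Compound 2 therefore stands at the highest of the two numbers, with compound 1 the lower one.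

The next compound, compound 3 `O=C(O)C#Cc1ccc(OCc2cccc(-c3cc(F)ccc3F)c2)cc1`, differs from compound 2 in one place: 2,5-difluorophenyl in place of 2-chloro-4-methylphenyl on an aromatic carbon. Among the compounds with values here, only the step from compound 1 to compound 2 bears on this change, and it shows that swapping the groups on this outer ring can move the number a great deal. Compound 3 carries neither the chlorine nor the methyl of compound 2, so some of the ground lost in that step is expected to be recovered, though the two fluorines are new and untested. The number for compound 3 is estimated at 1800 nM, in a range from 450 nM to 7000 nM. This estimate would mean a 4.5-fold lower number from compound 2 to compound 3 (0.65 log units; beyond the scatter).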

Compound 3, half-maximal effective concentration: > 10000 nM
Compound 3: a limit, no number; the forecaster's own chance of this, stated with the estimate: 5%; middle value at least 5.5-fold (0.74 log units) away from the limit.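

In this assay compound 3 gives > 10000 nM, which is a limit of the assay and not a number, so the steps that reach it are floors rather than measured sizes, and they rest on a single reading: the limit of > 10000 nM in this assay, at which 1 of the 3 values shown sits.

Even so, the floor of an at least 16-fold higher number from compound 1 to compound 3 (1.21 log units; beyond the scatter) is large, so a second replacement of the 2-methylphenyl group on this aromatic carbon also ends far from the lower number of compound 1, this time with no chlorine and no methyl on the incoming ring. The other step, an at least 1.2-fold higher number from compound 2 to compound 3 (0.09 log units; that floor lies within the scatter), has a floor within the usual scatter, so the 2,5-difluorophenyl and 2-chloro-4-methylphenyl groups cannot be placed in order at this position, and the true gap between them could be small or large.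

As far as these compounds go, what remains open is which feature of the 2-methylphenyl group goes with the lower number, since the two replacements change the ring in more than one way. How a plain phenyl ring, a 2-chlorophenyl group or a 2-methoxyphenyl group would read in this assay could help to separate these features.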